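Swapping 4-chlorophenyl for benzamidomethyl

A few compounds are considered here, and "the series" means these few. Any claim that something is new, unique, unknown or untested is made for them only; others in the source may bear on it.

compound 1 `Clc1ccc(-c2nnc(SCCCN3CCN(c4nc5ccccc5o4)CC3)o2)cc1` gives 121000 nM
compound 2 `Fc1ccc(-c2nnc(SCCCN3CCN(c4nc5ccccc5o4)CC3)o2)cc1` gives 83800 nM
compound 3 `Oc1ccc(-c2nnc(SCCCN3CCN(c4nc5ccccc5o4)CC3)o2)cc1` gives 502000 nM

In a functional assay on HepG2 cells (Homo sapiens) for inhibition, read by MTT assay, with a stated time of 72 h (a higher number here means a weaker inhibitor, a lower number a stronger inhibitor), compound 1 gives 121000 nM and lies within the scatter of compound 2, while compound 3 is the weakest of the three. Compound 4 `O=C(NCc1nnc(SCCCN2CCN(c3nc4ccccc4o3)CC2)o1)c1ccccc1` has not been measured yet. It carries benzamidomethyl in place of 4-chlorophenyl on an aromatic carbon, a change counted as benzamidomethyl in place of 4-chlorophenyl on an aromatic carbon in full. Among the compounds with values here, three measured steps bear on it. The first is a 1.4-fold lower number from compound 1 to compound 2 (0.16 log units; within the scatter) and is the smallest, while a 4.1-fold higher number from compound 1 to compound 3 (0.62 log units; beyond the scatter) and a 6.0-fold higher number from compound 2 to compound 3 (0.78 log units; beyond the scatter) are modest. None of them replaces the whole 4-chlorophenyl group, so they guide this swap only loosely. The two steps beyond the scatter both run towards a higher number, and that direction is the one tentatively expected in this assay here. The expected step is a 1.5-fold higher number from compound 1 to compound 4 (0.17 log units; within the scatter) and no step beyond the scatter is expected. For compound 4 the estimated value is 180000 nM with an expected range from 60000 nM to 500000 nM given the size of this swap.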

Compound 4, half-maximal inhibitory concentration: 88900 nM
Compound 4: the middle estimate sits 2.0-fold (0.31 log units) above what was measured; the measured number falls inside the stated range.
By their numbers in this assay, from the lowest: compounds 2, 4 and 1 (each within the scatter of the next); then compound 3.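

In this assay, this carbon of the five-membered ring accepts a much larger group that also carries an amide: benzamidomethyl in place of 4-chlorophenyl gives a 1.4-fold lower number from compound 1 to compound 4 (0.13 log units; within the scatter), and in place of 4-fluorophenyl it gives a 1.1-fold higher number from compound 2 to compound 4 (0.03 log units; within the scatter), both of which leave the number effectively unchanged. A para-substituted phenyl group on this carbon is therefore not required for numbers of this size, and the step of a 5.6-fold lower number from compound 3 to compound 4 (0.75 log units; beyond the scatter) shows that, among these four compounds, only compound 3 with its 4-hydroxyphenyl group stands apart. Nothing available explains why these groups give the numbers they do.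

On these data alone, it remains open whether the amide hydrogen matters, which a methylated amide would test. Whether an amine, a carboxylic acid or a longer chain on this carbon would shift the number beyond the scatter is also unresolved.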